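Notes on the step from compound 3 to compound 4

The source may report more compounds than this note shows. Statements on the series, on what has been measured and on what is new or still open speak of the compounds shown alone.

In an ADME assay on MT4 cells (Homo sapiens) for cytotoxicity, read by MTT assay (on this read-out lower numbers stand for higher toxicity in this test and higher numbers for lower toxicity in this test), compound 1 `CCCCCOc1ccc(C(=O)N(C(=S)OCCN2C(=O)c3ccccc3C2=O)c2ccc(F)cc2)cc1` reads > 100000 nM, which is a limit of the assay and not a number. Compound 2 `O=C1c2ccccc2C(=O)N1CCOC(=S)N(C(=O)c1ccc(C(F)(F)F)cc1)c1ccc(Cl)cc1` gives 10000 nM. Compound 3 `O=C1c2ccccc2C(=O)N1CCOC(=S)N(C(=O)c1ccc(Br)cc1)c1ccc(Br)cc1` gives 73000 nM, the higher of the two actual numbers in the series, and its gap to compound 2 lies beyond the scatter.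

Compound 4 `O=C1c2ccccc2C(=O)N1CCOC(=S)N(C(=O)c1cccnc1Cl)c1ccc(Br)cc1` has not yet been measured in this assay. Its difference from compound 3 is 2-chloropyridin-3-yl in place of 4-bromophenyl on a carbonyl carbon. Cut one bond further out, this reads (4-bromophenyl)carbonyl to (2-chloropyridin-3-yl)carbonyl.

Among the measured compounds shown here, no measured pair isolates this change. The expectation therefore rests on compound 3 at 73000 nM as the starting point, with compound 2 at 10000 nM showing how low a number this series has reached. A modest move towards a lower number is expected, with no step beyond the scatter. The expected step is a 1.6-fold lower number from compound 3 to compound 4 (0.21 log units; within the scatter). The estimate for compound 4 is 45000 nM, with an expected range from 14000 nM to 100000 nM.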

Compound 4, half-maximal cytotoxic concentration: > 100000 nM
Compound 4 was reported as a limit (the forecaster's own chance of this, stated with the estimate: 25%); at least 2.2-fold (0.34 log units) between middle value and limit.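

In this assay, among the compounds shown here, the first one-place change, 2-chloropyridin-3-yl in place of 4-bromophenyl on a carbonyl carbon, gives an at least 1.3-fold higher number from compound 3 to compound 4 (0.13 log units; that floor lies within the scatter), so this swap of the aromatic ring on the carbonyl produces no lower number. Compound 4 reads > 100000 nM, which is a limit of the assay and not a number. Only a floor can be read for this step, and its true size stays unknown, because compound 4 sits at the same end of the read-out as compound 1: the limit of > 100000 nM in this assay, at which 2 of the 4 values shown sit.

The compounds shown do not separate the ring nitrogen from the chlorine, and a pyridin-3-yl group without the chlorine, or a chlorophenyl group, on this carbonyl would be needed to tell the two apart. Also open, from the compounds shown here alone, is how a ring carrying an amine or a carboxylic acid on this carbonyl would read in this assay, and whether any such group would bring the number down from the limit.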